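Swapping the tolyl arm for a naphthyl arm on a low-activity series

A few compounds are considered here, and "the series" means these few. Any claim that something is new, unique, unknown or untested is made for them only; others in the source may bear on it.

Among the compounds with values here, the two compounds measured so far sit close to the floor of a functional assay on OVCAR-3 cells (Homo sapiens) for inhibition, read by sulforhodamine B assay, with a stated time of 48 h, tested at 10 uM; a lower number here means less inhibition, a higher number more inhibition at the concentration tested (going by the name of the read-out). Compound 1 `c1ccc2c(-c3cn4ccnc4c(-c4ccc5ncn(C6CCCCC6)c5c4)n3)cccc2c1` gives 2.38% in this assay, and compound 2 `Cc1cccc(-c2cn3ccnc3c(-c3ccc4ncn(Cc5ccccc5)c4c3)n2)c1` gives 14%, the higher of the two numbers, which puts compound 2 above compound 1 by a margin beyond the usual scatter.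

Compound 3 `c1ccc(Cn2cnc3ccc(-c4nc(-c5cccc6ccccc56)cn5ccnc45)cc32)cc1` has not yet been measured in this assay. It differs from compound 2 in one place: naphthalen-1-yl in place of 3-methylphenyl on an aromatic carbon.

Within the data shown here, no measured pair shows this exact change, so the size of the step is open. Compound 1, which gives 2.38%, shows that the series can sit even lower than compound 2, so a small downward step, within the scatter, is the expectation here. Compound 3 is thus estimated at 7% in this assay, within a range of 0% to 20%, meaning an expected step of a number 7 percentage points lower from compound 2 to compound 3 (within the scatter).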

Compound 3, a percentage reported as inhibition, at one concentration (the size of the read-out at that concentration, not a potency): 1.44%
Compound 3: middle estimate off by 5.6 percentage points, on the high side; the range from low to high includes it.
By their numbers in this assay, from the lowest: compounds 3 and 1 (each within the scatter of the next); then compound 2.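

In this assay, naphthalen-1-yl in place of 3-methylphenyl on the aromatic carbon gives a number 12.6 percentage points lower from compound 2 to compound 3 (beyond the scatter), the first measured sign that the number responds to the group at this position. With naphthalen-1-yl held in place, benzyl in place of cyclohexyl on the aromatic nitrogen gives a number 0.9 percentage points lower from compound 1 to compound 3 (within the scatter), so no effect of that swap can be read while this arm is present, and compound 3 stays as low in the assay as compound 1. Nothing measured here accounts for either step.

From the compounds shown here alone, whether an amine or a carboxylic acid on the aryl arm, or a longer chain on the aromatic nitrogen, would raise the number remains open. These readings come from a single concentration, so the potency of the series also remains unsettled.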